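The compounds below may be only part of what the source reports. "The series", "measured", "known", "first", "only" and "open" are said of these compounds alone.

Within the data shown here, compound 3 `CCc1ccc(C#Cc2nc(NC)c3ncn([C@H]4[C@H](O)[C@H](O)[C@]5(C(=O)NC)C[C@H]45)c3n2)o1` stands second highest of the three numbers so far in an assay on CHO cells for displacement of a labelled ligand from adenosine receptor A3 (Homo sapiens), read by scintillation counting, with a stated time of 60 min (a higher number here means a weaker inhibitor, a lower number a stronger inhibitor), giving 1.5 nM. Its nearest neighbour is compound 1 `CNC(=O)[C@@]12C[C@@H]1[C@@H](n1cnc3c(NC)nc(C#Cc4ccccc4OC)nc31)[C@H](O)[C@@H]2O`, which gives 0.77 nM, a gap read as a 1.9-fold higher number from compound 1 to compound 3 (0.29 log units; within the scatter). Its furthest is compound 2 `CNC(=O)[C@@]12C[C@@H]1[C@@H](n1cnc3c(NC)nc(C#Cc4cccnn4)nc31)[C@H](O)[C@@H]2O`, which gives 3.53 nM, a gap read as a 2.4-fold lower number from compound 2 to compound 3 (0.37 log units; beyond the scatter). Compound 4 `CNC(=O)[C@@]12C[C@@H]1[C@@H](n1cnc3c(NC)nc(C#Cc4cc5ccccc5o4)nc31)[C@H](O)[C@@H]2O` differs from compound 3 by 1-benzofuran-2-yl in place of 5-ethylfuran-2-yl on a triple-bonded carbon. Every measured step here swaps the group on the triple-bonded carbon, and none of those steps exceeded a modest size: a 4.6-fold higher number from compound 1 to compound 2 (0.66 log units; beyond the scatter), a 1.9-fold higher number from compound 1 to compound 3 (0.29 log units; within the scatter) and a 2.4-fold lower number from compound 2 to compound 3 (0.37 log units; beyond the scatter). Among the measured compounds shown here, no measured compound carries the entering group, so only a small step is expected for compound 4 in this assay, no change at the digits printed from compound 3 to compound 4 (within the scatter), with an estimate of 1.5 nM and a range from 0.5 nM to 4.5 nM.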

Compound 4, inhibition constant: 1.62 nM
Estimate against measurement, compound 4: 1.1-fold (0.03 log units) below; the range from low to high includes it.
By their numbers in this assay, from the lowest: compounds 1, 3 and 4 (each within the scatter of the next, the first and the last beyond it); then compound 2.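

In this assay, 1-benzofuran-2-yl, the only group shown on the triple-bonded carbon with a second aromatic ring, reads level with 5-ethylfuran-2-yl (a 1.1-fold higher number from compound 3 to compound 4 (0.03 log units; within the scatter)). Its steps to the other two groups stay modest (a 2.2-fold lower number from compound 2 to compound 4 (0.34 log units; beyond the scatter); a 2.1-fold higher number from compound 1 to compound 4 (0.32 log units; beyond the scatter)), so the larger group does not widen the spread of values at this position. Nothing available explains how closely these groups read. The compounds shown carry only aromatic groups at this position. As far as these compounds go, whether an amine, a carboxylic acid or a longer alkyl chain would give similar numbers remains open.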